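The source may hold more compounds than are shown below. What is called first, only, known or untested is meant among the compounds shown, and "the series" means these compounds.

In an ADME assay on microsomes from liver (Mus musculus) for metabolic stability, with a stated time of 10 min, tested at 0.5 uM (on this read-out higher numbers stand for a more stable compound and lower numbers for a less stable compound), compound 1 (`Cc1noc(C)c1[C@@H]1C[C@@](C)(c2ccc(F)cc2F)N=C(N)S1`) gives 72% and compound 2 (`Cc1noc(C)c1[C@@H]1C[C@@](C)(c2ccccc2)N=C(N)S1`) gives 78% with the two numbers within the usual scatter of each other. Compound 3 (`CCc1noc(C)c1[C@@H]1C[C@@](C)(c2ccc(F)cc2F)N=C(N)S1`) reads 41% and is the lowest of the three, beyond the scatter from both. Compound 4 (`CCc1noc(CC)c1[C@@H]1C[C@@](C)(c2ccc(F)cc2F)N=C(N)S1`) has not yet been measured. It differs from compound 3 by one change (methyl in place of hydrogen on a saturated chain carbon bound to an aromatic carbon), methyl in place of hydrogen on a saturated chain carbon bound to an aromatic carbon, which also reads as methyl to ethyl. Going by the values given here, one measured step bears on this, and it is the same kind of change: a number 31 percentage points lower from compound 1 to compound 3 (beyond the scatter) is a large step, beyond the scatter. Going by these compounds, it is a single instance, so how far it repeats remains open. A further fall in this assay is expected, probably smaller in size since compound 3 starts at 41% and has less left to lose. The expected step is a number 19 percentage points lower from compound 3 to compound 4 (beyond the scatter) on this reasoning. For compound 4 the estimated value is 22% with an expected range of 8% to 38% in this assay.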

Compound 4, percent of the compound remaining: 59%
The estimate for compound 4 lay 37 percentage points below the measured number; the measured number lies above the stated range.
By their numbers in this assay, from the lowest: compound 3; then compound 4; then compounds 1 and 2 (each within the scatter of the next).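

In this assay the same change, methyl to ethyl, does not act the same way each time: the earlier step was downward (a number 31 percentage points lower from compound 1 to compound 3 (beyond the scatter)), while this one is upward (a number 18 percentage points higher from compound 3 to compound 4 (beyond the scatter)). The direction of the step is therefore not fixed by the change alone, and the fall seen at the first place does not repeat at the second place on the shared core. Nothing shown here accounts for this reversal.

The compounds shown leave open whether the rise belongs to this place alone or appears only when the other ethyl is already present. They also leave open how the number would move with a longer chain such as propyl, or with an amine on the saturated chain carbon bound to an aromatic carbon.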